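From compound 3 to compound 4: a stability estimate

This account rests on a few compounds, and the source may have more. Where it says the series, first, only, none or still open, it means among the compounds named here.

In an in vitro ADME assay on microsomes (Mus musculus) for metabolic stability (a higher number here means that the compound lasts longer, a lower number that the compound disappears faster), compound 1 `CNC(=O)Nc1ccc(-c2nc(N3CC4CCC(C3)O4)c3cnn(C)c3n2)cc1` gives > 0.5 h, which is a limit and not a number. Compound 2 `CNC(=O)Nc1ccc(-c2nc(N3CC4CCC(C3)O4)c3cnn([C@H]4CC[C@@H](O)CC4)c3n2)cc1` gives > 0.5 h, again a limit. Compound 3 `CNC(=O)Nc1ccc(-c2nc(N3CC4CCC(C3)O4)c3cnn([C@H]4CC[C@H](OC)CC4)c3n2)cc1` gives > 0.5 h, also a limit. The series therefore stands at the limit of > 0.5 h in this assay, at which 3 of the 3 values shown sit, and compound 3 has no readable place within it.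

Compound 4 `CNC(=O)Nc1ccc(-c2nc(N3CC4CCC(C3)O4)c3cnn(C4CCC(OC)(OC)CC4)c3n2)cc1` changes the group on the aromatic nitrogen of compound 3: a group of 10 heavy atoms (8 carbon, 2 oxygen; one six-membered non-aromatic ring of carbon only) in place of a group of 8 heavy atoms (7 carbon, 1 oxygen; one six-membered non-aromatic ring of carbon only), on an aromatic nitrogen. Three measured steps change that same group: a step that the two limits leave unreadable from compound 1 to compound 2, a step that the two limits leave unreadable from compound 1 to compound 3 and a step that the two limits leave unreadable from compound 2 to compound 3. None has a readable size, so none gives a direction for the new change. A step beyond the usual scatter is therefore not expected, and the expected step is a step that the limit leaves unreadable from compound 3 to compound 4, with no direction implied. Another limit is the more likely report. As a number, the estimate for compound 4 is 0.7 h, with an expected range from 0.35 h to 1.5 h.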

Compound 4, half-life: 0.25 h
Compound 4: middle estimate off by 2.8-fold (0.45 log units), on the high side; measured number below the stated range.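

In this assay compound 4 gives 0.25 h, the only number among the groups shown on this aromatic nitrogen. The other values remain limits: the limit of > 0.5 h in this assay, at which 3 of the 4 values shown sit. The group of 10 heavy atoms gives an at least 2.0-fold lower number from compound 3 to compound 4 (0.30 log units; that floor lies within the scatter), an at least 2.0-fold lower number from compound 2 to compound 4 (0.30 log units; that floor lies within the scatter) and an at least 2.0-fold lower number from compound 1 to compound 4 (0.30 log units; that floor lies within the scatter), so this change shows a downward direction at the position, but each size is only a floor and does not by itself clear the scatter. The steps among compound 1, compound 2 and compound 3 cannot be read.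

Going by these compounds, how far the true size of these steps exceeds the floor remains open. Also open, on these data alone, is how an amine or a carboxylic acid on the cyclohexyl group, in place of the methoxy substitution, would read at this position.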